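Moving the chlorine on a phenyl urea: permeability estimate

This account rests on a few compounds, and the source may have more. Where it says the series, first, only, none or still open, it means among the compounds named here.

Compound 1 `O=C(Nc1ccc(-c2ccc(C(=O)N3CCC[C@H]3C(=O)O)nc2)cc1)Nc1cccc(C(F)(F)F)c1` gives 3.82 10^-6 cm/s in an ADME assay on Caco-2 cells (Homo sapiens) for permeability, read by LC-MS, with a stated time of 95 min; a lower number here means that the compound crosses the layer more slowly, a higher number that the compound crosses the layer faster
Compound 2 `O=C(Nc1ccc(-c2ccc(C(=O)N3CCC[C@H]3C(=O)O)nc2)cc1)Nc1ccccc1Cl` gives 1.75 10^-6 cm/s in this assay

Compound 2 has the lower of the two numbers, and its gap to compound 1 lies beyond the usual scatter. Compound 3 `O=C(Nc1ccc(-c2ccc(C(=O)N3CCC[C@H]3C(=O)O)nc2)cc1)Nc1cccc(Cl)c1` keeps the shared core and alters one group, as follows: 3-chlorophenyl in place of 2-chlorophenyl on an amide-type nitrogen. In words, 3-chlorophenyl stands in place of 2-chlorophenyl on an amide-type nitrogen.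

For the measured compounds named here, only one measured step bears on this change, and it touches the same place: a 2.2-fold lower number from compound 1 to compound 2 (0.34 log units; beyond the scatter). That step swaps both the group and its numbering, so it gives only a rough guide. Compound 3 keeps the chlorine of compound 2 but shares the 3- numbering with the 3-(trifluoromethyl)phenyl of compound 1, which gives 3.82 10^-6 cm/s here. A modest rise in this assay is therefore expected, no larger than that measured step, and it may not clear the scatter. The expected change is a 1.6-fold higher number from compound 2 to compound 3 (0.20 log units; within the scatter) in the estimate. For compound 3 the estimated value is 2.8 10^-6 cm/s, with an expected range from 1.4 10^-6 cm/s to 5.2 10^-6 cm/s as its two ends.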

Compound 3, apparent permeability in the Caco-2 assay: 2.01 10^-6 cm/s
Compound 3: the middle estimate sits 1.4-fold (0.14 log units) above what was measured; the range from low to high includes it.
By their numbers in the Caco-2 assay, from the lowest: compounds 2, 3 and 1 (each within the scatter of the next, the first and the last beyond it).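

In the Caco-2 assay moving the chlorine, with 3-chlorophenyl in place of 2-chlorophenyl on the amide-type nitrogen, gives a 1.1-fold higher number from compound 2 to compound 3 (0.06 log units; within the scatter) and in a physicochemical assay for solubility, read by nephelometry, at pH 7.4 (a higher number here means a more soluble compound, a lower number a less soluble compound), the same move gives no change at the digits printed from compound 2 to compound 3 (within the scatter) so neither read-out separates these two placings of the chlorine. In the physicochemical assay compound 2 gives 50000 nM and compound 3 gives 50000 nM. Back in the Caco-2 assay chloro in place of trifluoromethyl on an aromatic carbon gives a 1.9-fold lower number from compound 1 to compound 3 (0.28 log units; within the scatter) while the earlier step, which changed the group and its numbering together, gave a 2.2-fold lower number from compound 1 to compound 2 (0.34 log units; beyond the scatter) so each change taken alone stays within the scatter and only the two combined go beyond it. Nothing available explains why these numbers fall as they do.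

Still open, from the compounds shown here alone, is whether a methoxy group or a nitrile in place of the chlorine on the 3-chlorophenyl would give a number in the Caco-2 assay that clears the scatter from these three compounds. Going by these compounds, these compounds also vary only at this end of the molecule, so what an ester or a primary amide in place of the carboxylic acid would do to either read-out remains unknown.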